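Swapping the indole of compound 2 for phenyl

A few compounds are considered here, and "the series" means these few. Any claim that something is new, unique, unknown or untested is made for them only; others in the source may bear on it.

- Compound 1 `COc1cc(-c2cc3nccc(-c4cc(OC)c(OC)c(OC)c4)n3n2)cc(OC)c1OC`: > 10000 nM (a limit of the assay, not a number)
- Compound 2 `COc1cc(-c2ccnc3cc(-c4c[nH]c5ccccc45)nn23)cc(OC)c1OC`: 85 nM
- Compound 3 `Cn1ccc2cc(-c3cc4nccc(-c5ccc(F)cc5)n4n3)ccc21`: 4580 nM

These three compounds were tested in a functional assay on MCF7 cells (Homo sapiens) for inhibition, read by CCK-8 assay, with a stated time of 48 h; on this read-out lower numbers stand for stronger inhibition and higher numbers for weaker inhibition. Only two of them gave true numbers, and compound 2 has the lower one at 85 nM. The nearest number belongs to compound 3 at 4580 nM, and that gap lies beyond the usual scatter. Compound 1 stands at > 10000 nM, which is a limit of the assay.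

Compound 4 `COc1cc(-c2ccnc3cc(-c4ccccc4)nn23)cc(OC)c1OC` has not yet been measured. It differs from compound 2 in one place, with phenyl in place of 1H-indol-3-yl on an aromatic carbon. Among the compounds with values here, no measured pair isolates this change, so any expectation is indirect. Among the three measured compounds, only compound 2 carries 1H-indol-3-yl. Compound 3 lacks that group and gives 4580 nM, so the same loss in compound 4 is expected to raise the number, meaning weaker inhibition, by well beyond the scatter. The expected size of this change is a 24-fold higher number from compound 2 to compound 4 (1.37 log units; beyond the scatter). For compound 4 the estimated value is 2000 nM, with an expected range from 400 nM to 8000 nM.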

Compound 4, half-maximal inhibitory concentration: 254 nM
Compound 4: the middle estimate sits 7.9-fold (0.90 log units) above what was measured, and the stated range ends above it.
By their numbers in this assay, from the lowest: compound 2; then compound 4; then compound 3. At a limit, above all of these: compound 1.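

Within the data shown here, this pair gives the first single-change reading of this position: the shared core stays the same, and in this assay putting phenyl in place of 1H-indol-3-yl on this aromatic carbon gives a 3.0-fold higher number from compound 2 to compound 4 (0.48 log units; beyond the scatter) and no larger loss. The step is modest but lies beyond the scatter, so 1H-indol-3-yl gives stronger inhibition here without being required, as a plain phenyl with only a six-membered carbon ring and no hydrogen-bond donor still leaves compound 4 with a true number rather than a limit. Nothing measured in this set speaks to what lies behind the size of this step.

The swap removes the five-membered ring and its hydrogen-bond donor together, so this pair cannot say which of them accounts for the step. A naphthyl group, which keeps a second ring without the ring nitrogen, would help to separate the two, while a small methyl group or an amine on the same carbon would show how much this position needs an aromatic ring at all.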